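Phenoxy in Place of Trifluoromethoxy on the Pendant Ring

A few compounds are considered here, and "the series" means these few. Any claim that something is new, unique, unknown or untested is made for them only; others in the source may bear on it.

Compound 1 `Cc1ccc(-c2onc3ccc(/C=C/C(=O)O)cc23)cc1` gives 6510 nM in an assay for inhibition of inositol hexakisphosphate kinase 2 (Homo sapiens), read by colorimetric assay, coupled enzyme assay and malachite green, with a stated time of 120 min, in the presence of a further agent that is not named here; on this read-out lower numbers stand for stronger inhibition and higher numbers for weaker inhibition.
Compound 2 `O=C(O)/C=C/c1ccc2noc(-c3ccc(OC(F)(F)F)cc3)c2c1` gives 320 nM in this assay.

Among the compounds with values here, on these two numbers compound 2 stands lowest, and its only neighbour is compound 1, from which it is separated by a 20-fold lower number from compound 1 to compound 2 (1.31 log units; beyond the scatter), the change being trifluoromethoxy in place of methyl on an aromatic carbon. Compound 3 `O=C(O)/C=C/c1ccc2noc(-c3ccc(Oc4ccccc4)cc3)c2c1` differs from compound 2 by phenyl in place of trifluoromethyl on an oxygen on an aromatic ring. Within the data shown here, no measured step covers this exchange; the one step on record, a 20-fold lower number from compound 1 to compound 2 (1.31 log units; beyond the scatter), shows only that what sits at this position can move the number a great deal. Among the measured compounds shown here, with no direct precedent, a modest step is expected for compound 3, the direction uncertain, estimated as a 1.6-fold higher number from compound 2 to compound 3 (0.19 log units; within the scatter). Compound 3 is therefore expected to give about 500 nM in this assay, with a range from 100 nM to 3000 nM.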

Compound 3, half-maximal inhibitory concentration: 94 nM
Beside the measured number, compound 3's estimate is 5.3-fold (0.73 log units) above it, outside the stated range (below it).
By their numbers in this assay, from the lowest: compound 3; then compound 2; then compound 1.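

In this assay the oxygen on the aromatic ring can carry a whole six-membered aromatic ring as well as a small fluorinated group: phenyl in place of trifluoromethyl gives a 3.4-fold lower number from compound 2 to compound 3 (0.53 log units; beyond the scatter) and so the number falls further with the larger group. Set against the methyl of the starting point, phenoxy gives a 69-fold lower number from compound 1 to compound 3 (1.84 log units; beyond the scatter) and goes beyond what trifluoromethoxy reached, so in these compounds the fall at this position does not depend on fluorine. Nothing measured here accounts for why this exchange moves the number.

On these data alone, how the number would respond to a cyclohexyloxy or benzyloxy group in place of phenoxy stays open. So does the part played by the oxygen itself, which a phenyl set directly on the pendant ring would test.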